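The source may report more compounds than this note shows. Statements on the series, on what has been measured and on what is new or still open speak of the compounds shown alone.

The four compounds share one core and differ only in the group carried on the sulfonyl sulfur. Compound 1 `CC1CCN(C2CCN(S(=O)(=O)c3ccc(C(C)(C)C)cc3)CC2)CC1` was tested in a functional assay on DLD-1 cells (Homo sapiens) for antiproliferative activity, read by CellTiter-Glo, with a stated time of 72 h; on this read-out lower numbers stand for stronger inhibition and higher numbers for weaker inhibition. In this assay compound 1 gives > 5000 nM, which is a limit of the assay rather than a number. Among the measured compounds shown here, compound 3 `CC1CCN(C2CCN(S(=O)(=O)c3cccc4cnccc34)CC2)CC1` is the only member with a numerical result: in this assay compound 3 gives 225 nM. Compound 2 `Cc1noc(C)c1S(=O)(=O)N1CCC(N2CCC(C)CC2)CC1` carries the 3,5-dimethyl-1,2-oxazol-4-yl group. In this assay compound 2 gives > 5000 nM, again a limit of the assay and not a number. Compound 2 therefore stands at the limit of > 5000 nM in this assay, at which 2 of the 3 values shown sit, outside the range in which the assay returns a value, while compound 3 alone lies inside it. For the measured compounds named here, no step between two measured compounds is available, so nothing here tells how one group on the sulfonyl sulfur compares with another.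

Compound 4 `Cc1ccc(S(=O)(=O)N2CCC(N3CCC(C)CC3)CC2)cc1C` has not yet been measured. It differs from compound 2 by 3,4-dimethylphenyl in place of 3,5-dimethyl-1,2-oxazol-4-yl on a sulfonyl sulfur. Compound 1 also carries a six-membered aromatic ring of carbon only on the sulfonyl sulfur and reached only the limit of the assay. Compound 4 is thus expected to give 5000 nM in this assay, with a likely range from 1500 nM to 20000 nM. The expected step is a number no higher from compound 2 to compound 4 (the limit leaves the size open), that is none beyond the scatter.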

Compound 4, half-maximal inhibitory concentration: 24 nM
Estimate against measurement, compound 4: 210-fold (2.32 log units) above, outside the stated range (below it).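

Setting 3,4-dimethylphenyl in place of 3,5-dimethyl-1,2-oxazol-4-yl on a sulfonyl sulfur gives an at least 200-fold lower number from compound 2 to compound 4 (2.31 log units; beyond the scatter) in this assay, the first step in this series that can be read, and it shows that the group at this place can carry the result from the limit of the assay into the low range of measured values. As far as these compounds go, the full size of the step stays unknown, and the printed figure is only a minimum, because compound 2 stands at a limit of the assay and not at a number: the limit of > 5000 nM in this assay, at which 2 of the 4 values shown sit A six-membered aromatic ring of carbon only is not enough by itself, since compound 1 also carries one and gives > 5000 nM, which is a limit of the assay.

The compounds shown leave open whether a plain phenyl, or a phenyl with a single methyl, would keep the result of compound 4, and how an amine or a carboxylic acid on that ring would fare. All of them keep the shared core, so they say nothing about a change made there.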